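Switching the chain terminus from aminomethyl to a guanidine-bearing group

The source may hold more compounds than are shown below. What is called first, only, known or untested is meant among the compounds shown, and "the series" means these compounds.

Measured compounds:
- compound 1, `CC1(C)N(O)C(c2ccc(O)cc2)=[N+]([O-])C1(C)C`: 49100 nM
- compound 2, `CC1(C)N(O)C(c2ccc(OCC(=O)N[C@@H](CCCCN)C(=O)O)cc2)=[N+]([O-])C1(C)C`: 30100 nM

Of the compounds shown here, two sharing the same core have been measured in a functional assay on PC-12 cells (Rattus norvegicus) for inhibition, read by MTT assay; on this read-out lower numbers stand for an effect already at smaller amounts and higher numbers for an effect only at larger amounts of compound. Compound 1 gives 49100 nM in this assay, and compound 2, which carries the longer side chain ending in an aminomethyl group, gives 30100 nM. Compound 2 has the lower of the two numbers, but its nearest neighbour is compound 1, and the gap between them lies within the usual scatter, so the two values should be read as alike.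

Compound 3, `CC1(C)N(O)C(c2ccc(OCC(=O)N[C@@H](CCCNC(=N)N)C(=O)O)cc2)=[N+]([O-])C1(C)C`, has not yet been measured. It differs from compound 2 by a group of 4 heavy atoms (1 carbon, 3 nitrogen; no ring) in place of a group of 2 heavy atoms (1 carbon, 1 nitrogen; no ring), on a saturated chain carbon, four bonds along the chain from an amide-type nitrogen and a carbonyl carbon: the aminomethyl at the chain end is replaced by a group of 1 carbon and 3 nitrogen atoms, sitting on a saturated chain carbon four bonds along the chain from an amide-type nitrogen and a carbonyl carbon. Among the measured compounds shown here, since no measured pair covers such a change, the expectation is a step of no more than the scatter in either direction, and the estimated step is a 1.2-fold lower number from compound 2 to compound 3 (0.06 log units; within the scatter). Compound 3 is therefore expected to give about 26000 nM in this assay, with a likely range from 10000 nM to 65000 nM.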

Compound 3, half-maximal effective concentration: 32100 nM
For compound 3 the middle estimate is 1.2-fold (0.09 log units) below the measured one; measured number inside the range.
By their numbers in this assay, from the lowest: compounds 2, 3 and 1 (each within the scatter of the next).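

In this assay, among the compounds shown here, the replacement at this position, on a saturated chain carbon, four bonds along the chain from an amide-type nitrogen and a carbonyl carbon, gives a 1.1-fold higher number from compound 2 to compound 3 (0.03 log units; within the scatter) and so offers the first direct reading of a structural variation at the chain end. Exchanging the aminomethyl, with 1 hydrogen-bond donor, for the group of 4 heavy atoms (1 carbon, 3 nitrogen), with 3 hydrogen-bond donors and 1 double bond, does not separate compound 2 from compound 3 on this read-out, so the two must be read as alike despite the larger end group. No measurement at hand offers an explanation for this result.

The compounds shown leave open whether any other group at this position would produce a step beyond the scatter, for example a carboxylic acid or a dimethylamino group at the chain end, or a hydroxyl in place of the terminal nitrogen group. They also leave open how a shorter or a longer chain carrying the same terminal groups would read in this assay.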